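Carbonyl substituent variation in an acylidene penam series

The source may report more compounds than this note shows. Statements on the series, on what has been measured and on what is new or still open speak of the compounds shown alone.

Measured compounds:
compound 1, `CC1(C)S[C@@H]2/C(=C\C(=O)c3ccc4ccccc4c3)C(=O)N2[C@H]1C(=O)OC(c1ccccc1)c1ccccc1`, 19500 nM
compound 2, `CC1(C)S[C@@H]2/C(=C\C(=O)c3ccc(C(F)(F)F)cc3)C(=O)N2[C@H]1C(=O)OC(c1ccccc1)c1ccccc1`, 15600 nM
compound 3, `CCOC(=O)/C=C1/C(=O)N2[C@@H]1SC(C)(C)[C@@H]2C(=O)OC(c1ccccc1)c1ccccc1`, 11200 nM

The three compounds share one core and differ only in the group on the carbonyl carbon attached to the double-bonded chain carbon. In a functional assay on OE19 cells (Homo sapiens) for cytotoxicity, read by MTT assay, with a stated time of 48 h (a higher number here means a weaker inhibitor, a lower number a stronger inhibitor), compound 3 gives the lowest of the three numbers, but its gap to the others is small: a 1.4-fold lower number from compound 2 to compound 3 (0.14 log units; within the scatter) and a 1.7-fold lower number from compound 1 to compound 3 (0.24 log units; within the scatter) both fall within the scatter, as does a 1.3-fold lower number from compound 1 to compound 2 (0.10 log units; within the scatter). For the measured compounds named here, on these numbers no compound can be separated from another.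

Compound 4, `CC(=O)/C=C1/C(=O)N2[C@@H]1SC(C)(C)[C@@H]2C(=O)OC(c1ccccc1)c1ccccc1`, continues the same line of change: methyl in place of ethoxy on a carbonyl carbon. Every measured step here bears on it, since each also exchanges the group on that carbonyl carbon, and none of them moved this assay beyond the scatter. The change from ethoxy to methyl is smaller in size than any of those exchanges, so no step beyond the scatter is expected in this assay in either direction; the expected step is a 1.2-fold higher number from compound 3 to compound 4 (0.06 log units; within the scatter).

For compound 4 the estimate in this assay is 13000 nM, with a range from 5000 nM to 35000 nM.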

Compound 4, half-maximal inhibitory concentration: 51900 nM
The estimate for compound 4 lay 4.0-fold (0.60 log units) below the measured number; measured number outside the range, above it.
By their numbers in this assay, from the lowest: compounds 3, 2 and 1 (each within the scatter of the next); then compound 4.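

In this assay this position proves not indifferent to the group on the carbonyl carbon: there is a 4.6-fold higher number from compound 3 to compound 4 (0.67 log units; beyond the scatter) and a 3.3-fold higher number from compound 2 to compound 4 (0.52 log units; beyond the scatter) and also a 2.7-fold higher number from compound 1 to compound 4 (0.43 log units; beyond the scatter) so compound 4 is the weakest of the four, although each of these steps is modest, while exchanges among ethoxy, 4-(trifluoromethyl)phenyl and naphthalen-2-yl stayed within the scatter. Having carbon rather than oxygen attached to that carbonyl does not by itself go with the higher number, since compound 1 and compound 2 also carry carbon there and remain within the scatter of compound 3. No measurement shown here explains why methyl separates from the other three groups.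

On these data alone, whether the higher number belongs to methyl alone or extends to other small chains stays open, and ethyl, isopropyl or a longer chain on the same carbonyl carbon would test this, as would a hydrogen or an amine there. As far as these compounds go, all of this rests on a single cell line, so whether the same separation appears in other cells also remains open.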